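Benzylic amide variation in an orexin receptor binding series

The source may hold more compounds than are shown below. What is called first, only, known or untested is meant among the compounds shown, and "the series" means these compounds.

Compound 1 `Cc1cc(C)cc(-c2cnc(-c3cccnc3)c(C(=O)N(C)Cc3ccc4nccnc4c3)c2)c1`: 7250 nM
Compound 2 `COc1ccc(CNC(=O)c2cc(-c3cc(C)cc(C)c3)cnc2-c2cccnc2)cc1`: 2980 nM

Both compounds were tested in an assay on isolated protein for displacement of a labelled ligand from Orexin/Hypocretin receptor type 1 (Homo sapiens), read by scintillation counting, with a stated time of 60 min; a lower number here means a stronger inhibitor, a higher number a weaker inhibitor. Compound 1 gives 7250 nM, and compound 2 gives 2980 nM. Compound 2 therefore stands with the lowest number of the two, and its gap to compound 1 is beyond the scatter, so compound 2 is the stronger inhibitor of this pair.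

Compound 3 `Cc1cc(C)cc(-c2cnc(-c3cccnc3)c(C(=O)NCc3ccc(F)c(C)c3)c2)c1` has not yet been measured in this assay. It differs from compound 2 in one place: 4-fluoro-3-methylphenyl in place of 4-methoxyphenyl on a saturated chain carbon bound to an amide-type nitrogen. For the measured compounds named here, no measured pair in this set shows what such a change does, so the direction of the step is uncertain. The step from compound 2 to compound 3 is expected to be small, a 1.2-fold lower number from compound 2 to compound 3 (0.08 log units; within the scatter), and may well lie within the scatter. Compound 3 is estimated at 2500 nM, in a range from 700 nM to 9000 nM.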

Compound 3, inhibition constant: 1110 nM
Beside the measured number, compound 3's estimate is 2.3-fold (0.35 log units) above it; measured number inside the range.
By their numbers in this assay, from the lowest: compound 3; then compound 2; then compound 1.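

In this assay, for the compounds shown here, the benzyl group on the amide nitrogen proves responsive to substitution on its ring: the change gives a 2.7-fold lower number from compound 2 to compound 3 (0.43 log units; beyond the scatter), the first single-place comparison in this set. The step is modest but beyond the scatter, and it comes with the same count of heavy atoms and a six-membered aromatic ring of carbon only on both sides, so the number moved with the substituents alone changing. Nothing available here accounts for this shift.

Because the fluorine and the methyl enter together as the methoxy leaves, the compounds shown cannot tell which of these carries the step, and 4-fluorophenyl or 3-methylphenyl alone would be needed to separate them. Going by these compounds, what a longer chain in place of the benzylic carbon would do also remains open.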